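Shrinking the amine substituent on a shared benzimidazole-type core

The source may hold more compounds than are shown below. What is called first, only, known or untested is meant among the compounds shown, and "the series" means these compounds.

Compound 2 `CN(c1nc2ccc(NC(=O)CCc3ccc(C(F)(F)F)cc3)cc2[nH]1)C1CCOC1` carries a methyl(oxolan-3-yl)amino group on its core and, in an assay on CHO-K1 cells for displacement of a labelled ligand from melanin-concentrating hormone receptor 1 (Homo sapiens), read by scintillation counting (on this read-out higher numbers stand for weaker inhibition and lower numbers for stronger inhibition), compound 2 gives 27 nM, the lowest of the two numbers reported. Compound 3 `CC(C)N(C)c1nc2ccc(NC(=O)c3cncc(-c4ccc(F)cc4)c3)cc2[nH]1`, which bears a different amide and an isopropyl(methyl)amino group, gives 900 nM in this assay. Compound 1 `CC(C)N(C)c1nc2ccc(NC(=O)CCc3ccc(C(F)(F)F)cc3)cc2s1`, a sulfur-containing analogue, reaches only a limit of this assay, > 750 nM, so its true number is not known; the limit itself is the limit of > 750 nM in this assay, at which 1 of the 3 values shown sits.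

Compound 4 `CN(C)c1nc2ccc(NC(=O)CCc3ccc(C(F)(F)F)cc3)cc2[nH]1` is the not-yet-measured analogue of compound 2 in which the change is methyl in place of oxolan-3-yl on a nitrogen on an aromatic ring, giving a dimethylamino group. Within the data shown here, no two measured compounds differ by this change alone, so the step cannot be read off directly. Because compound 2 gives 27 nM with the larger group, a moderate weakening is expected, beyond the scatter but well short of the gap to compound 3. The step from compound 2 to compound 4 is expected to be about a 4.1-fold higher number from compound 2 to compound 4 (0.61 log units; beyond the scatter). Compound 4 is thus estimated at 110 nM, most likely between 35 nM and 400 nM.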

Compound 4, half-maximal inhibitory concentration: 12 nM
Compound 4: the middle estimate sits 9.2-fold (0.96 log units) above what was measured, outside the stated range (below it).
By their numbers in this assay, from the lowest: compound 4; then compound 2; then compound 3.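

In this assay, putting methyl in place of oxolan-3-yl on a nitrogen on an aromatic ring gives a 2.3-fold lower number from compound 2 to compound 4 (0.35 log units; beyond the scatter) and so moves the number down, not up. Among these compounds, this is the first direct reading at this position: the five-membered ring with its oxygen can be removed without any loss, and the much smaller dimethylamino group does at least as well here. Nothing measured on these compounds explains why the smaller group gives the lower number.

This single pair sets no trend for group size at this position. The compounds shown leave open how an ethyl group or a cyclopentyl ring would behave there, and a cyclopentyl ring would keep the five-membered ring while removing its oxygen.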